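The source may report more compounds than this note shows. Statements on the series, on what has been measured and on what is new or still open speak of the compounds shown alone.

Compound 1, `Cc1cc(C)c(-c2cn(C)cn2)cc1NC(=O)c1ccc(OCc2ccccn2)cc1`, gives 8000 nM in a physicochemical assay for solubility, at pH 7.4; a higher number here means a more soluble compound, a lower number a less soluble compound.
Compound 2, `Cc1cc(C)c(-c2ccccn2)cc1NC(=O)c1ccc(OCc2ccccn2)cc1`, gives only a limit in this assay, namely < 1000 nM.

Within the data shown here, the one measured step, an at least 8.0-fold lower number from compound 1 to compound 2 (0.90 log units; beyond the scatter), rests on that limit; (the limit of < 1000 nM in this assay, at which 1 of the 2 values shown sits). Compound 2 therefore stands at the low end of the numbers shown, without a number of its own.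

Compound 3, `Cc1cc(C)c(-c2ccc(N)cn2)cc1NC(=O)c1ccc(OCc2ccccn2)cc1`, is not yet measured. It differs from compound 2 by amino in place of hydrogen on an aromatic carbon. Among the measured compounds shown here, no measured step concerns this kind of change, so no measured step bears on it directly. Compound 3 is therefore estimated to stay near the floor where compound 2 sits, at 1500 nM, between 500 nM and 5000 nM, which would mean an expected step of an at least 1.5-fold higher number from compound 2 to compound 3 (0.17 log units; that floor lies within the scatter).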

Compound 3, solubility: < 1000 nM
Compound 3: only a limit was reported; the forecaster's own chance of this, stated with the estimate: 45%; at least 1.5-fold (0.17 log units) between middle value and limit.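

Amino on the six-membered aromatic ring, two atoms from the ring nitrogen, does not give compound 3 a number of its own in this assay, only a limit. Setting 5-aminopyridin-2-yl in place of 1-methyl-1H-imidazol-4-yl still gives an at least 8.0-fold lower number from compound 1 to compound 3 (0.90 log units; beyond the scatter), so amino does not bring back the level of compound 1. The step between compound 2 and compound 3 cannot be read: the limit of < 1000 nM in this assay, at which 2 of the 3 values shown sit.

From the compounds shown here alone, whether amino shifts the value at all beneath that limit stays open. Also open, going by these compounds, is whether a carboxylic acid or an aminomethyl group at this position would rise clear of the limit in this assay.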